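From Hydroxy to Dimethylamino on the Shared Core

This account rests on a few compounds, and the source may have more. Where it says the series, first, only, none or still open, it means among the compounds named here.

Going by the values given here, in a functional assay on HT-29 cells (Homo sapiens) for antiproliferative activity, with a stated time of 48 h (on this read-out lower numbers stand for an effect already at smaller amounts and higher numbers for an effect only at larger amounts of compound), compound 1 `O=C(CCCCCCC(=O)Nc1ccc(O)cc1)NO` gives 15000 nM, the highest number so far. Compound 2 `O=C(CCCCCCC(=O)Nc1cccc(F)c1)NO` gives 1400 nM, and compound 3 `O=C(CCCCCCC(=O)Nc1cccc(Cl)c1)NO` gives 1000 nM. Compound 4 `CN(C)c1ccc(NC(=O)CCCCCCC(=O)NO)cc1` has dimethylamino in place of hydroxy on an aromatic carbon, para to a large group (dimethylamino in place of hydroxy on an aromatic carbon). Among the compounds with values here, the only measured step between close relatives, a 1.4-fold lower number from compound 2 to compound 3 (0.15 log units; within the scatter), exchanges chloro for fluoro and says nothing direct about this change. Within the data shown here, the one clue is that compound 2 and compound 3, neither carrying hydroxy, both sit well under compound 1, so a lower number is expected here too, though with real uncertainty. The estimated step is a 5.0-fold lower number from compound 1 to compound 4 (0.70 log units; beyond the scatter). For compound 4 the expected value is 3000 nM, with an estimated range of 1000 nM to 9000 nM.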

Compound 4, half-maximal effective concentration: 3150 nM
Estimate against measurement, compound 4: 1.1-fold (0.02 log units) below; the measured number falls inside the stated range.
By their numbers in this assay, from the lowest: compounds 3 and 2 (each within the scatter of the next); then compound 4; then compound 1.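

In this assay, going by these compounds alone, putting dimethylamino in place of hydroxy on an aromatic carbon, para to a large group, gives a 4.8-fold lower number from compound 1 to compound 4 (0.68 log units; beyond the scatter), the first direct measurement of a change at this position. The step is modest, and the entering group brings more heavy atoms and no hydrogen-bond donor. Nothing measured here explains the lower number. Since those two differences arrive together, the compounds shown cannot separate them. As far as these compounds go, whether a methoxy or an amino group in the same place would land nearer compound 1 or compound 4 remains open.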